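Nitro for Bromo on a Paw Edema Read-out

This account rests on a few compounds, and the source may have more. Where it says the series, first, only, none or still open, it means among the compounds named here.

Measured compounds:
Compound 1, `Cc1ccc2c(Cc3nn4cc(-c5ccc(Cl)cc5)nc4s3)coc2c1`: 51.7%
Compound 2, `Cc1ccc2c(Cc3nn4cc(-c5ccc(Br)cc5)nc4s3)coc2c1`: 10.9%

In a functional assay on the whole organism (strain Wistar albino) for inhibition, with Rattus norvegicus as the target, read by paw edema, with a stated time of 3 h, at a dose of 100 mg/kg by the oral route (on this read-out higher numbers stand for more inhibition at the one dose given (going by the name of the read-out) and lower numbers for less inhibition), compound 1 gives 51.7%. Going by the values given here, compound 2 gives 10.9%, the lowest of the two numbers, and its only neighbour is compound 1, which stands well beyond the scatter above it. Compound 3, `Cc1ccc2c(Cc3nn4cc(-c5ccc([N+](=O)[O-])cc5)nc4s3)coc2c1`, has not yet been measured. It differs from compound 2 in one place: nitro in place of bromo on an aromatic carbon. Among the compounds with values here, only one measured step exists, a number 40.8 percentage points lower from compound 1 to compound 2 (beyond the scatter), and it exchanges one halogen for another, so it does not bear directly on a nitro group. It does show that a single change at this position can move the read-out by a large amount in either direction. Within the data shown here, with no nitro analogue measured, the expectation for compound 3 is held wide: compound 3 is estimated to give 32%, between 5% and 62%, with the expected step being a number 21.1 percentage points higher from compound 2 to compound 3 (beyond the scatter).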

Compound 3, a percentage reported as inhibition, in the whole organism at one dose (the size of the read-out at that dose, not a potency): 40.9%
For compound 3 the middle estimate is 8.9 percentage points below the measured one, within the range that was stated.
By their numbers in this assay, from the lowest: compound 2; then compound 3; then compound 1.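

In this assay, nitro in place of bromo gives a number 30 percentage points higher from compound 2 to compound 3 (beyond the scatter), so the low number of compound 2 does not extend to every replacement at this place on the ring. Nitro in place of chloro gives a number 10.8 percentage points lower from compound 1 to compound 3 (beyond the scatter), which recovers much of the lost inhibition but leaves compound 1 the highest of the three, and the two single-atom halogens sit at opposite ends of the order with the larger nitro group in the middle. Nothing here explains why these groups differ as they do.

From the compounds shown here alone, whether an amine, a carboxylic acid or a methoxy group at this same place would fall nearer compound 1 or compound 2 remains open. Going by these compounds, each number also comes from a single dose, so the order at other doses is unknown.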